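Swapping the Ester for a Basic Amide

This account rests on a few compounds, and the source may have more. Where it says the series, first, only, none or still open, it means among the compounds named here.

Going by the values given here, compound 2 `CCOC(=O)CN(c1cccc(Cl)c1)S(=O)(=O)c1cccc(NC(=O)CN(C)C(=O)OCc2ccccc2)c1` gives 35% in a functional assay on HEK293 cells for antagonist activity at Voltage-dependent T-type calcium channel subunit alpha-1H (Homo sapiens), read by patch clamp, tested at 1 uM (a lower number here means less inhibition, a higher number more inhibition at the concentration tested (going by the name of the read-out)), the lower of the two numbers measured so far; compound 1 `CC(C)OC(=O)CN(c1cccc(Cl)c1)S(=O)(=O)c1cccc(NC(=O)CN(C)C(=O)OCc2ccccc2)c1` gives 78%. Among the compounds with values here, the single step known, a number 43 percentage points lower from compound 1 to compound 2 (beyond the scatter), came with hydrogen in place of methyl on a saturated chain carbon bound to an oxygen next to a carbonyl group and a saturated chain carbon, so even a small trimming on that side of the molecule was felt strongly. Compound 3 `CN(C)CCNC(=O)CN(c1cccc(Cl)c1)S(=O)(=O)c1cccc(NC(=O)CN(C)C(=O)OCc2ccccc2)c1` carries the change ((2-(dimethylamino)ethyl)amino in place of ethoxy on a carbonyl carbon). Within the data shown here, no measured step covers this kind of exchange, an amide in place of an ester; the one step known shows only that this part of the molecule matters, not which way a larger change will go. With no closer guide, compound 3 is expected to land near compound 2, a step of a number 5 percentage points higher from compound 2 to compound 3 (within the scatter) within the scatter. The estimate for compound 3 is 40%, with a range from 15% to 70%.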

Compound 3, a percentage reported as inhibition, at one concentration (the size of the read-out at that concentration, not a potency): 22%
For compound 3 the middle estimate is 18 percentage points above the measured one; the measured number falls inside the stated range.
By their numbers in this assay, from the lowest: compound 3; then compound 2; then compound 1.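

In this assay, putting (2-(dimethylamino)ethyl)amino in place of ethoxy on this carbonyl carbon gives a number 13 percentage points lower from compound 2 to compound 3 (beyond the scatter), so this larger amine-bearing chain does not restore the inhibition lost on trimming isopropoxy to ethoxy. Set against isopropoxy, the same kind of exchange gives a number 56 percentage points lower from compound 1 to compound 3 (beyond the scatter), which leaves isopropoxy as the best of the three groups shown at this position. Nothing shown gives a reason for these drops.

The exchange alters both the atom bound to the carbonyl carbon and the far end of the chain, so the compounds shown cannot separate those two changes. A plain methylamino group would test the amide link without the dimethylamino end, while tert-butoxy or a free carboxylic acid would show how far the trend among the esters extends.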